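Ethoxymethyl in place of methoxymethyl on a shared core

A few compounds are considered here, and "the series" means these few. Any claim that something is new, unique, unknown or untested is made for them only; others in the source may bear on it.

Measured so far:
Compound 1 `CCCOCNc1n[n+]([O-])c2cc(OC)ccc2[n+]1[O-]` gives 4280 nM
Compound 2 `O=[N+]([O-])c1cccc(COCNc2n[n+]([O-])c3ccccc3[n+]2[O-])c1` gives 5650 nM
Compound 3 `COCNc1n[n+]([O-])c2ccccc2[n+]1[O-]` gives 7800 nM

All three compounds share one core and differ in the chain on the amine. In a functional assay on K562 cells (Homo sapiens) for cytotoxicity, read by MTT assay, with a stated time of 72 h (a higher number here means a weaker inhibitor, a lower number a stronger inhibitor), compound 3 gives the highest of the three numbers, yet its gaps to compound 2 and to compound 1 both lie within the usual scatter of repeated measurements, so the three stand together rather than apart.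

Compound 4 `CCOCNc1n[n+]([O-])c2ccccc2[n+]1[O-]` has not yet been measured. It differs from compound 3 by one change, (methyl in place of hydrogen on a saturated chain carbon bound to an oxygen on a saturated carbon). Among the measured compounds shown here, no pair of measured compounds differs in one place, so the size of such a step has not been seen here. The three numbers shown lie close to one another across several different chains, which suggests that a small change of this kind is expected to move this assay little, if at all, beyond the scatter, and in no firm direction.

The step from compound 3 to compound 4 is therefore expected to be a 1.2-fold lower number from compound 3 to compound 4 (0.08 log units; within the scatter). Compound 4 is estimated at 6500 nM, with a range from 2800 nM to 15000 nM.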

Compound 4, half-maximal inhibitory concentration: 15400 nM
The estimate for compound 4 lay 2.4-fold (0.37 log units) below the measured number; the measured number lies above the stated range.
By their numbers in this assay, from the lowest: compounds 1, 2, 3 and 4 (each within the scatter of the next, the first and the last beyond it).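

In this assay, among the compounds shown here, the change from methoxymethyl to ethoxymethyl supplies the only step here between compounds that differ in one place, a 2.0-fold higher number from compound 3 to compound 4 (0.30 log units; within the scatter), which the earlier compounds could not provide. It shows that methyl in place of hydrogen on this saturated chain carbon bound to an oxygen on a saturated carbon does not move the number beyond the scatter, so no real change can be claimed for this position from this single pair. Nothing measured here bears on the reason for this step.

The compounds shown leave open whether a longer chain, such as propoxymethyl, on the core of compound 3 would move the number beyond the scatter. They also leave open what an amine or a carboxylic acid at the end of this chain would do.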